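A Saturated Ring Becomes an Aromatic One

A few compounds are considered here, and "the series" means these few. Any claim that something is new, unique, unknown or untested is made for them only; others in the source may bear on it.

In an ADME assay on L6 cells (Rattus norvegicus) for cytotoxicity (a lower number here means a stronger inhibitor, a higher number a weaker inhibitor), compound 1 (`CCOC(=O)c1noc2c1CN(C(=O)c1cc(C(C)C)c(O)cc1O)CC2`) gives 563 nM and compound 2 (`CCNC(=O)c1noc(-c2cc(C(C)C)c(O)cc2O)c1NC(=O)C1CCC(OC)CC1`) gives 15 nM while compound 3 (`CCNC(=O)c1nnn(-c2cc(C(C)C)c(O)cc2O)c1-c1ccc(CC2CCCC2)cc1`) gives 8 nM in the same test. Compound 2 thus stands far below compound 1, a gap beyond the usual scatter, and compound 2 and compound 3 lie within the scatter of each other. Compound 4 (`CCNC(=O)c1noc(-c2cc(C(C)C)c(O)cc2O)c1NC(=O)c1ccc(OC)cc1`) carries 4-methoxyphenyl in place of 4-methoxycyclohexyl on a carbonyl carbon. Within the data shown here, no measured pair shows this change, so the expectation rests on compound 2 (15 nM) as the nearest measured relative. The expected step is a 1.3-fold higher number from compound 2 to compound 4 (0.12 log units; within the scatter) and it should stay within the scatter. For compound 4 the estimated value is 20 nM (expected range 6 nM to 70 nM).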

Compound 4, half-maximal inhibitory concentration: 7 nM
For compound 4 the middle estimate is 2.9-fold (0.46 log units) above the measured one, within the range that was stated.
By their numbers in this assay, from the lowest: compounds 4, 3 and 2 (each within the scatter of the next, the first and the last beyond it); then compound 1.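

Among these compounds, this is the first pair here that differs in only one place, so it gives the first direct reading of this carbonyl position. In this assay, the change from a saturated ring to an aromatic one gives a 2.1-fold lower number from compound 2 to compound 4 (0.33 log units; beyond the scatter) and so has a modest effect, even though the heavy-atom count, hydrogen-bond donors and acceptors stay the same. Nothing available explains the shift.

As far as these compounds go, how a pyridine ring or a 4-chlorophenyl group would read at this carbonyl carbon remains open. So does whether the methoxy group contributes to the step.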